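A few compounds are considered here, and "the series" means these few. Any claim that something is new, unique, unknown or untested is made for them only; others in the source may bear on it.

Measured compounds

compound 1, `COc1cc2nc(N3CCN(S(=O)(=O)c4ccc(C)cc4)CC3)nc(N)c2cc1OC`: 30000 nM
compound 2, `COc1cc2nc(N3CCN(S(=O)(=O)c4ccc(C(F)(F)F)cc4)CC3)nc(N)c2cc1OC`: 27000 nM
compound 3, `COc1cc2nc(N3CCN(S(=O)(=O)c4ccc(-c5ccc(C)cc5)cc4)CC3)nc(N)c2cc1OC`: 3400 nM

All three share one core and differ only in the group on the outer aromatic ring. In a functional assay on PC-3 cells (Homo sapiens) for inhibition (on this read-out lower numbers stand for stronger inhibition and higher numbers for weaker inhibition), the step of a 1.1-fold lower number from compound 1 to compound 2 (0.05 log units; within the scatter) is made by the change (trifluoromethyl in place of methyl on an aromatic carbon); the two values are indistinguishable. The change 4-methylphenyl in place of methyl on an aromatic carbon gives the step of an 8.8-fold lower number from compound 1 to compound 3 (0.95 log units; beyond the scatter), and a 7.9-fold lower number from compound 2 to compound 3 (0.90 log units; beyond the scatter) is of like size. Compound 3 therefore stands apart from compound 1 and compound 2, and its value is the lowest of the three.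

Compound 4, `COc1cc2nc(N3CCN(S(=O)(=O)c4ccc(-c5ccc(C(F)(F)F)cc5)cc4)CC3)nc(N)c2cc1OC`, is not yet measured. It differs from compound 3 by trifluoromethyl in place of methyl on an aromatic carbon. The same change, at the same place, is already seen in the pair compound 1 to compound 2, where it made the step of a 1.1-fold lower number from compound 1 to compound 2 (0.05 log units; within the scatter). The change thus appears in two pairs; in the measured one it left the value unchanged within the scatter. The only grounds for an expectation on compound 4 are that step and the value of compound 3.

For compound 4 the expected step in this assay is a 1.1-fold lower number from compound 3 to compound 4 (0.04 log units; within the scatter), a step expected to stay within the scatter because the same change gave a 1.1-fold lower number from compound 1 to compound 2 (0.05 log units; within the scatter). The estimate for compound 4 in this assay is 3100 nM, with an expected range from 1500 nM to 6500 nM.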

Compound 4, half-maximal inhibitory concentration: 3300 nM
Compound 4: middle estimate off by 1.1-fold (0.03 log units), on the low side; measured number inside the range.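

In this assay, trifluoromethyl in place of methyl leaves the value as unchanged on the core of compound 3 as on the core of compound 1, with a 1.0-fold lower number from compound 3 to compound 4 (0.01 log units; within the scatter), and the two steps agree: the same change on two cores in this assay, a 1.1-fold lower number (0.05 log units; within the scatter) from compound 1 to compound 2 and a 1.0-fold lower number (0.01 log units; within the scatter) from compound 3 to compound 4, 1.1-fold (0.03 log units) apart, within the scatter of two such steps

The larger steps in the series go with the second aromatic ring, and that holds for the 4-(trifluoromethyl)phenyl group too, with an 8.2-fold lower number from compound 2 to compound 4 (0.91 log units; beyond the scatter) and a 9.1-fold lower number from compound 1 to compound 4 (0.96 log units; beyond the scatter), so compound 3 and compound 4 sit together, apart from compound 1 and compound 2. Going by these compounds alone, this shows only that a change without visible effect stays without visible effect across these two cores in this one assay; it does not show that the change would be as silent on other cores or in other read-outs, nor that a change with a real effect would carry over in the same way.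

Open, going by these compounds, is whether an amine or a carboxylic acid at the end of the 4-substituted phenyl group would move the value where methyl and trifluoromethyl do not. Also open, on these data alone, is whether a longer chain in place of the second aromatic ring would give a step of the same size.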